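A few compounds are considered here, and "the series" means these few. Any claim that something is new, unique, unknown or untested is made for them only; others in the source may bear on it.

Compound 1 `S=C(N/N=C/c1ccc2ccccc2n1)Nc1ccc(Br)cc1`, compound 2 `Fc1cccc(NC(=S)N/N=C/c2ccc3ccccc3n2)c1` and compound 3 `NC(=S)N/N=C/c1cc2ccccc2s1` share one core and have been tested in a functional assay on SGC-7901 cells (Homo sapiens) for antiproliferative activity, read by sulforhodamine B assay, with a stated time of 72 h; a lower number here means a stronger inhibitor, a higher number a weaker inhibitor. Compound 1 gives 69400 nM. Compound 2 gives 79900 nM, and the step of a 1.2-fold higher number from compound 1 to compound 2 (0.06 log units; within the scatter) shows the two sitting together. Compound 3 gives a limit of the assay rather than a number, > 100000 nM. Among the two plain numbers, compound 2 holds the higher one, yet with compound 1 so close no order between them can be claimed, and one of the three values already rests at the limit of > 100000 nM in this assay, at which 1 of the 3 values shown sits.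

Compound 4 `COc1cccc(NC(=S)N/N=C/c2ccc3ccccc3n2)c1` differs from compound 2 by methoxy in place of fluoro on an aromatic carbon. Going by the values given here, the only measured step touching the same part of the molecule is a 1.2-fold higher number from compound 1 to compound 2 (0.06 log units; within the scatter), a swap of one small substituent on that ring, which moved the number no further than the scatter. By that precedent, the step of a 1.0-fold higher number from compound 2 to compound 4 (0.00 log units; within the scatter) is expected to stay within the scatter as well. Compound 4 is therefore estimated at 80000 nM, most likely between 35000 nM and 180000 nM.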

Compound 4, half-maximal inhibitory concentration: 79400 nM
Compound 4: middle estimate off by 1.0-fold (0.00 log units), on the high side; low and high end bracket the measured number.
By their numbers in this assay, from the lowest: compounds 1, 4 and 2 (each within the scatter of the next). At a limit, above all of these: compound 3.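

Putting methoxy in place of fluoro on this ring gives a 1.0-fold lower number from compound 2 to compound 4 (0.00 log units; within the scatter), so the entering group's extra heavy atom and hydrogen-bond acceptor leave no readable mark on the result in this assay. The wider swap to 3-methoxyphenyl in place of 4-bromophenyl gives a 1.1-fold higher number from compound 1 to compound 4 (0.06 log units; within the scatter), and that also stays within the scatter. Compounds 1, 2 and 4 now show three different aryl groups on the amide-type nitrogen with no step beyond the scatter, and none of the three goes against that.

From the compounds shown here alone, whether an amine or a carboxylic acid on this ring would move the number beyond the scatter remains open. Compound 3 has a limit of the assay rather than a number, so it gives no size of step to compare: the limit of > 100000 nM in this assay, at which 1 of the 4 values shown sits.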